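A few compounds are considered here, and "the series" means these few. Any claim that something is new, unique, unknown or untested is made for them only; others in the source may bear on it.

Measured compounds:
compound 1 `CO[C@]1(c2cc(F)cc(Sc3ccc(/C(C)=N/O)cc3)c2)CCO[C@@H](C)C1`: 40 nM
compound 2 `CO[C@]1(c2cc(F)cc(Sc3ccc(/C(C)=N/OCC#N)cc3)c2)CCO[C@@H](C)C1`: 40 nM
compound 3 `CO[C@]1(c2cc(F)cc(S(=O)(=O)c3ccc(/C(C)=N/OCC#N)cc3)c2)CCO[C@@H](C)C1`: 60 nM

All three numbers come from a functional assay (blood) for inhibition, with Homo sapiens as the target; a lower number here means a stronger inhibitor, a higher number a weaker inhibitor. Compound 2 and compound 1 differ in a single place: hydrogen in place of cyanomethyl on an oxygen. This change left the read-out unchanged, no change at the digits printed from compound 2 to compound 1 (within the scatter). Compound 3 keeps the cyanomethyl group of compound 2 on the same oxygen but differs from compound 2 elsewhere; the difference between the two cores is not broken down here. In this assay compound 3 gives 60 nM, and the gap from that number to the number of compound 1 and to the number of compound 2 lies within the usual scatter, so no ordering among the three is claimed.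

Compound 4 `CO[C@]1(c2cc(F)cc(S(=O)(=O)c3ccc(/C(C)=N/O)cc3)c2)CCO[C@@H](C)C1` has not been measured. It is related to compound 3 by hydrogen in place of cyanomethyl on an oxygen, the place being described in the same words as for the pair compound 2 to compound 1, so this is the same change made on the core of compound 3. One instance of the change is on record and it was flat. The expectation for compound 4 therefore rests on that single precedent and on the number of compound 3: the step of no change at the digits printed from compound 3 to compound 4 (within the scatter) is expected to be small, because no change at the digits printed from compound 2 to compound 1 (within the scatter) showed no change. In this assay compound 4 is estimated at 60 nM. Going by the values given here, the estimated range for compound 4 runs from 30 nM to 130 nM, wide enough to cover the ordinary scatter and the fact that only one prior instance of the change exists.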

Compound 4, half-maximal inhibitory concentration: 20 nM
Compound 4: the middle estimate sits 3.0-fold (0.48 log units) above what was measured; measured number below the stated range.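

In this assay, hydrogen in place of cyanomethyl on the oxygen bonded to the double-bonded nitrogen gives a 3.0-fold lower number from compound 3 to compound 4 (0.48 log units; beyond the scatter), whereas the same change on the other core gives no change at the digits printed from compound 2 to compound 1 (within the scatter). The change therefore does not carry over with the same size from one core to the other, and the flat step cannot be taken as a general rule for this series: the same change on two cores in this assay, no change at the digits printed (within the scatter) from compound 2 to compound 1 and a 3.0-fold lower number (0.48 log units; beyond the scatter) from compound 3 to compound 4, 3.0-fold (0.48 log units) apart, beyond the scatter of two such steps

This comparison rests on one pair of compounds per core, so it shows that the size of the step differed between these two cores, but it does not give the cause of that difference or show how the change would read on a third core.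

The compounds shown carry only hydrogen or cyanomethyl on this oxygen, so it remains open how a methyl group, or a longer chain ending in an amine or a carboxylic acid, would read on either core. Also open, on these data alone, is whether the step seen on the core of compound 3 would recur with other groups on that oxygen or would remain specific to the loss of cyanomethyl.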